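The source may report more compounds than this note shows. Statements on the series, on what has been measured and on what is new or still open speak of the compounds shown alone.

Measured in a functional assay on Jurkat cells (Homo sapiens) for inhibition, read by CCK-8 assay, with a stated time of 48 h; a lower number here means a stronger inhibitor of growth, a higher number a weaker inhibitor of growth:
- compound 1 `Cc1ccccc1Nc1nc(NCc2ccncc2)ncc1Cl`: > 100000 nM
- compound 2 `Cc1ccccc1Nc1nc(Nc2ccc(N3CCCCC3)cn2)ncc1Cl`: > 100000 nM
- compound 3 `CN1CCN(c2ccc(Nc3ncc(Cl)c(NCc4ccc(F)cc4)n3)nc2)CC1`: > 100000 nM

Each of these entries is a limit of the assay and not a number. Compound 3 has no measured potency, only the limit > 100000 nM. It shares this position with the other two compounds, so the whole set rests at one point: the limit of > 100000 nM in this assay, at which 3 of the 3 values shown sit.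

Compound 4 `Cc1ccc(Nc2nc(Nc3ccc(N4CCN(C)CC4)cn3)ncc2Cl)cc1` keeps the core of compound 3 and changes one group: 4-methylphenyl in place of 4-fluorobenzyl on a nitrogen on an aromatic ring. In words, 4-methylphenyl stands in place of 4-fluorobenzyl on a nitrogen on an aromatic ring.

No measured step between any two of these compounds shows what a single change does in this assay. Any expectation therefore has little support. A small move towards stronger growth inhibition is expected, though another reading at the limit is about as likely. The expected step of an at least 2.0-fold lower number from compound 3 to compound 4 (0.30 log units; that floor lies within the scatter) is estimated from a starting point that is only a limit. For compound 4 the estimated value is 50000 nM, with an expected range from 5000 nM to 100000 nM.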

Compound 4, concentration for 50% growth inhibition: 30900 nM
The estimate for compound 4 lay 1.6-fold (0.21 log units) above the measured number; the range from low to high includes it.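

Compound 4 is the only one of the four compounds shown that gives a measured number in this assay, so this position is the first place where a change moves the read-out off the shared limit. Replacing 4-fluorobenzyl with 4-methylphenyl on a nitrogen on an aromatic ring gives an at least 3.2-fold lower number from compound 3 to compound 4 (0.51 log units; beyond the scatter), which is a floor and not a full size, since the starting entry is a limit. The rest of the set still sits at one point: the limit of > 100000 nM in this assay, at which 3 of the 4 values shown sit.

The compounds shown leave open whether the shift belongs to the methyl group, or to the loss of the benzyl link with the ring now set directly on the nitrogen. A plain phenyl, a 4-fluorophenyl or a 4-methoxyphenyl on that nitrogen would separate these readings.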